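Inverting the Hydroxyethyl Stereocentre on an Amine-Bound Chain

A few compounds are considered here, and "the series" means these few. Any claim that something is new, unique, unknown or untested is made for them only; others in the source may bear on it.

Three measured compounds share one core and differ only on the chain bound to the amine nitrogen. In a functional assay on the whole organism (strain ddY) with Mus musculus as the target, in the formalin test, at a dose of 100 mg/kg by the oral route (a higher number here means more inhibition at the dose given (going by the name of the read-out), a lower number less inhibition), compound 1 `CC(C)(O)CNCC(=O)N1CCc2ccccc2C1C1CCCCC1` gives 7.7%, compound 2 `CC[C@@H](O)CNCC(=O)N1CCc2ccccc2C1C1CCCCC1` gives 19% and compound 3 `C[C@@H](O)CNCC(=O)N1CCc2ccccc2C1C1CCCCC1` gives 39%. Compound 3 stands highest of the three: the step of a number 20 percentage points higher from compound 2 to compound 3 (beyond the scatter) and the step of a number 31.3 percentage points higher from compound 1 to compound 3 (beyond the scatter) both lie beyond the scatter, as does a number 11.3 percentage points higher from compound 1 to compound 2 (beyond the scatter).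

Compound 4 `C[C@H](O)CNCC(=O)N1CCc2ccccc2C1C1CCCCC1` differs from compound 3 in this way: the two compounds have the same atoms and bonds; at least one stereo element is drawn with a configuration in one of them and without one in the other: 1 of 2 stereo elements differ; a stereocentre at a saturated chain carbon is drawn R in compound 3 and S in compound 4. Going by the values given here, none of the measured steps bears directly on this change; each of them alters what is attached to the saturated chain carbon rather than how the stereocentre is drawn. Those steps, modest to large, do show that this part of the molecule is where the read-out moves in this assay. Because a change on the saturated chain carbon moved the read-out by a number 20 percentage points higher from compound 2 to compound 3 (beyond the scatter), the inverted stereocentre of compound 4 is expected to shift the number as well, most likely downward from the highest value, though a step within the scatter cannot be ruled out. The estimated step of a number 14 percentage points lower from compound 3 to compound 4 (beyond the scatter) would leave compound 4 with an expected 25%, in a range from 5% to 45%.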

Compound 4, a percentage reported as inhibition, in the whole organism at one dose (the size of the read-out at that dose, not a potency): 0%
The estimate for compound 4 lay 25 percentage points above the measured number, outside the stated range (below it).
By their numbers in this assay, from the lowest: compounds 4 and 1 (each within the scatter of the next); then compound 2; then compound 3.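

The earlier compounds shown here showed that what is attached to the saturated chain carbon moves the read-out in this assay; this result shows that the configuration drawn at that carbon also moves it, with no atom or bond changed: a number 39 percentage points lower from compound 3 to compound 4 (beyond the scatter). The 1-hydroxyethyl group therefore does not secure the higher numbers on its own, since in its S form it gives a number 19 percentage points lower from compound 2 to compound 4 (beyond the scatter), set against the 1-hydroxypropyl chain, and a number 7.7 percentage points lower from compound 1 to compound 4 (within the scatter), set against the 1-hydroxy-1-methylethyl chain. Tying the step between the R and S forms to this one stereocentre requires one caution, which comes from how the two structures are drawn: the fact that one of compounds 3 and 4 is drawn with a defined configuration and the other without, at the place where they differ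

The compounds shown leave open whether the 1-hydroxypropyl chain depends on its configuration in the same way, and whether a longer chain such as 1-hydroxybutyl would continue the series. They also leave open what a methoxy group or an amine in place of the hydroxyl on this chain would do to the read-out at this single dose.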